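Chloro on a Fused Aromatic Carbon in Two Related Series

A few compounds are considered here, and "the series" means these few. Any claim that something is new, unique, unknown or untested is made for them only; others in the source may bear on it.

Compound 1 `Cc1cnc(Nc2ccc(S(C)(=O)=O)cc2)nc1Nc1nc2ccc(Cl)cc2s1`: in a functional assay on PC-3 cells (Homo sapiens) for antiproliferative activity, read by MTT assay, with a stated time of 48 h (on this read-out lower numbers stand for stronger inhibition and higher numbers for weaker inhibition), compound 1 gives 13400 nM.
Compound 2 `Cc1cnc(Nc2ccc(S(C)(=O)=O)cc2)nc1Nc1nc2ccccc2s1`: compound 2 reaches only the limit > 50000 nM in this assay.
Compound 3 `NS(=O)(=O)c1ccc(Nc2ncc(F)c(Nc3nc4ccccc4s3)n2)cc1`: compound 3 likewise reaches only the limit > 50000 nM in this assay.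

The pair compound 2 and compound 1 differ in one place, (chloro in place of hydrogen on an aromatic carbon), and this gave an at least 3.7-fold lower number from compound 2 to compound 1 (0.57 log units; beyond the scatter), a step measured against (the limit of > 50000 nM in this assay, at which 2 of the 3 values shown sit). How the core of compound 3 differs from the core of compound 2 is not broken down here. Compound 4 `NS(=O)(=O)c1ccc(Nc2ncc(F)c(Nc3nc4ccc(Cl)cc4s3)n2)cc1` has not yet been measured; it stands to compound 3 as compound 1 stands to compound 2, with the same change, (chloro in place of hydrogen on an aromatic carbon), at a place described in the same words. Since compound 3 sits at the limit > 50000 nM, a step of similar size is expected, an at least 2.5-fold lower number from compound 3 to compound 4 (0.39 log units; beyond the scatter), resting on the measured pair. Compound 4 is therefore estimated at 20000 nM, with a range from 6000 nM to 60000 nM, and it may again return only a limit.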

Compound 4, half-maximal inhibitory concentration: 1430 nM
Compound 4: the middle estimate sits 14-fold (1.15 log units) above what was measured; measured number outside the range, below it.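

Chloro in place of hydrogen on an aromatic carbon lowered the number again in this assay, this time with an at least 34-fold lower number from compound 3 to compound 4 (1.54 log units; beyond the scatter), so the direction seen on the core of compound 2 also held on the core of compound 3. Set side by side, the two steps read: the same change on two cores in this assay, an at least 3.7-fold lower number (0.57 log units; beyond the scatter) from compound 2 to compound 1 and an at least 34-fold lower number (1.54 log units; beyond the scatter) from compound 3 to compound 4; the limit leaves it open whether they differ. This does not show that the change is worth the same amount on both cores, or give the true size of either step, as both pairs start from a limit: the limit of > 50000 nM in this assay, at which 2 of the 4 values shown sit.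

The compounds shown carry only chloro at this place, so it remains open whether fluoro, bromo, methyl or methoxy there would lower the number in this assay on either core. On these data alone, it also remains open which of the differences between the two cores bears on the size of the step, and whether the change would carry over to a core with an amine or a carboxylic acid on its outer aromatic ring.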